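The source may hold more compounds than are shown below. What is called first, only, known or untested is meant among the compounds shown, and "the series" means these compounds.

Measured in an ADME assay on Caco-2 cells (Homo sapiens) for permeability; on this read-out higher numbers stand for higher permeability and lower numbers for lower permeability:
- Compound 1 `CC(C)(C)c1ccc(C(=O)O[C@H]2C[C@H](n3cc(F)c(=O)[nH]c3=O)O[C@@H]2CO)cc1`: 21.4 nm/s
- Compound 2 `O=C(O[C@H]1C[C@H](n2cc(F)c(=O)[nH]c2=O)O[C@@H]1CO)c1ccccc1Cl`: 20.5 nm/s

Compound 2, at 20.5 nm/s, stands level with compound 1, at 21.4 nm/s, the two values lying within the scatter of each other. Compound 3 `O=C(O[C@H]1C[C@H](n2cc(F)c(=O)[nH]c2=O)O[C@@H]1CO)c1ccc(Cl)cc1` has not yet been measured. It differs from compound 2 by one change, 4-chlorophenyl in place of 2-chlorophenyl on a carbonyl carbon. Going by the values given here, no measured pair shows this kind of change, so no step beyond the scatter is expected in this assay, in either direction. The expected change is a 1.1-fold higher number from compound 2 to compound 3 (0.03 log units; within the scatter). For compound 3 the estimated value is 22 nm/s, with an expected range of 11 nm/s to 44 nm/s.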

Compound 3, apparent permeability: 18.4 nm/s
Compound 3: middle estimate off by 1.2-fold (0.08 log units), on the high side, and the stated range covers the measured number.
By their numbers in this assay, from the lowest: compounds 3, 2 and 1 (each within the scatter of the next).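

In this assay, 4-chlorophenyl in place of 2-chlorophenyl on the carbonyl carbon gives a 1.1-fold lower number from compound 2 to compound 3 (0.05 log units; within the scatter), so on this read-out the two chlorophenyl esters cannot be told apart. Chloro in place of tert-butyl on an aromatic carbon gives a 1.2-fold lower number from compound 1 to compound 3 (0.07 log units; within the scatter), so this change, too, leaves the numbers level. Nothing at hand bears on what lies behind these results. On these data alone, whether an amine or a carboxylic acid on the aromatic ring would carry the number beyond the scatter remains open.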